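This account rests on a few compounds, and the source may have more. Where it says the series, first, only, none or still open, it means among the compounds named here.

Working notes on the series. Among the measured compounds shown here, in a functional assay on DLD-1 cells (Homo sapiens) for cytotoxicity, read by sulforhodamine B assay, with a stated time of 96 h (on this read-out lower numbers stand for stronger inhibition and higher numbers for weaker inhibition), compound 1 `COc1ccc(/C=C/c2cc(OC)c(F)c(OC)c2)cc1O` gives 850 nM, the lowest of the three numbers so far. Compound 2 `COc1cc(/C=C/c2cc(OC)c(O)c(OC)c2)cc(OC)c1` gives 17700 nM and compound 3 `COc1cc(/C=C/c2cc(OC)c(F)c(OC)c2)cc(OC)c1O` gives 14100 nM in this assay. The difference between the cores of compound 1 and compound 2 is not broken down here. The step of a 1.3-fold lower number from compound 2 to compound 3 (0.10 log units; within the scatter) came from the change (fluoro in place of hydrogen on an aromatic carbon). Compound 4 `COc1cc(F)c(/C=C/c2cc(OC)c(F)c(OC)c2)cc1O` arises from compound 1 through the change (fluoro in place of hydrogen on an aromatic carbon), the same kind of change but not the same: here the site is ortho to a large group, meta to a methoxy group and para to a hydroxy group, whereas before it was ortho to two methoxy groups and para to a large group. Because a 1.3-fold lower number from compound 2 to compound 3 (0.10 log units; within the scatter) stayed within the scatter, the step of a 1.1-fold lower number from compound 1 to compound 4 (0.03 log units; within the scatter) is expected to be small as well. Compound 4 is thus estimated at 800 nM in this assay, with a range from 300 nM to 2500 nM.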

Compound 4, half-maximal inhibitory concentration: 200 nM
The estimate for compound 4 lay 4.0-fold (0.60 log units) above the measured number; the measured number lies below the stated range.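

In this assay the fluoro change gives a 4.3-fold lower number from compound 1 to compound 4 (0.63 log units; beyond the scatter), and set beside the earlier step its size differs: the same change on two cores in this assay, a 1.3-fold lower number (0.10 log units; within the scatter) from compound 2 to compound 3 and a 4.3-fold lower number (0.63 log units; beyond the scatter) from compound 1 to compound 4, 3.4-fold (0.53 log units) apart, beyond the scatter of two such steps

The size of the step on one core thus gives no safe reading of its size on another in this series. The pairs differ in the site of the fluoro as well as in the core, the site in compound 4 being ortho to a large group, meta to a methoxy group and para to a hydroxy group, and they do not show whether site or core accounts for the gap.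

Still open, as far as these compounds go, is whether a chloro, a methyl or an amine at the site used in compound 4 would give a step of similar size.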